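The source may report more compounds than this note shows. Statements on the series, on what has been measured and on what is new or still open speak of the compounds shown alone.

Measured compounds:
compound 1 `Cn1ncnc1-c1ccccc1NCC1=NCCN1` gives 39.8 nM
compound 2 `CCCn1ncnc1-c1ccccc1NCC1=NCCN1` gives 316 nM
compound 3 `CC(C)n1ncnc1-c1ccccc1NCC1=NCCN1` gives a limit, < 100000 nM

In an in vitro functional assay on cells (Fibroblast) for agonist activity at Alpha-1B adrenergic receptor (Homo sapiens) (on this read-out lower numbers stand for an effect already at smaller amounts and higher numbers for an effect only at larger amounts of compound), compound 1 has the lowest of the two numbers; its nearest neighbour is compound 2, with a 7.9-fold higher number from compound 1 to compound 2 (0.90 log units; beyond the scatter). The value of compound 3 is a limit of the assay, not a number (the limit of < 100000 nM in this assay, at which 1 of the 3 values shown sits). The step that the limit leaves unreadable from compound 1 to compound 3 and the step that the limit leaves unreadable from compound 2 to compound 3 are therefore both unreadable in size.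

Compound 4 `Cc1nc(-c2ccccc2NCC2=NCCN2)n(C)n1` differs from compound 1 by methyl in place of hydrogen on an aromatic carbon. Among the measured compounds shown here, none of the measured steps touches the same position: the steps among compounds 1, 2 and 3 all change the group on the aromatic nitrogen, and the only readable one, a 7.9-fold higher number from compound 1 to compound 2 (0.90 log units; beyond the scatter), shows a modest rise in the number when the core of compound 1 carries more carbon. The change to compound 4 adds a single carbon on an aromatic carbon, so a smaller shift in the same direction is expected, though a step within the scatter cannot be excluded.

The expected step is a 2.5-fold higher number from compound 1 to compound 4 (0.40 log units; beyond the scatter). Compound 4 is estimated at 100 nM in this assay, with a range from 30 nM to 400 nM.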

Compound 4, half-maximal effective concentration: < 5020 nM
Compound 4: no number, only a limit; the forecaster's own chance of this, stated with the estimate: 5%; the middle value does not contradict the limit.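

In this assay compound 4 gives < 5020 nM, which is a limit and not a number, and the step from compound 1 to compound 4 cannot be read. The compounds shown leave open how large a change methyl in place of hydrogen on an aromatic carbon makes to the read-out, and in which direction.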